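A shorter chain at the assay's limit

This account rests on a few compounds, and the source may have more. Where it says the series, first, only, none or still open, it means among the compounds named here.

In a functional assay on HEL cells (Homo sapiens) (a lower number here means that less compound is tolerated, a higher number that more compound is tolerated), compound 3 `CCCCCCCCCc1cc2cn(COCCO)c(=O)nc2o1` gives >= 100000 nM, which is a limit and not a number. This is the limit of >= 100000 nM in this assay, at which 1 of the 3 values shown sits.

Compound 4 `CCCCCCc1cc2cn(COCCO)c(=O)nc2o1` has not yet been measured. Its structure differs from that of compound 3 as follows: hydrogen in place of propyl on a saturated chain carbon, six bonds along the chain from an aromatic carbon. In words, hydrogen stands in place of propyl on a saturated chain carbon, six bonds along the chain from an aromatic carbon, so that hexyl becomes propyl.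

Among the compounds with values here, the only measured step of this kind comes from a different core. In this assay, compound 1 `CCCCCCCCCCCc1cc2cn(COCCO)c(O)nc-2n1` gives 41000 nM and compound 2 `CCCCCCCCc1cc2cn(COCCO)c(O)nc-2n1` gives 65000 nM. There, hydrogen replaces propyl on a saturated chain carbon, eight bonds along the chain from an aromatic carbon, and the result is a 1.6-fold higher number from compound 1 to compound 2 (0.20 log units; within the scatter). With that single step inside the scatter as the guide, no change beyond the scatter is expected in this assay, and no direction is firmly expected either.

The expected step is a number no higher from compound 3 to compound 4 (the limit leaves the size open). Compound 4 is estimated at 100000 nM, with an expected range from 50000 nM to 200000 nM. It may well return only a limit too.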

Compound 4, half-maximal cytotoxic concentration: > 200000 nM
Compound 4: a limit, no number; the forecaster's own chance of this, stated with the estimate: 60%; middle value at least 2.0-fold (0.30 log units) from the limit.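

In this assay, within the data shown here, compound 3 and compound 4 each return only a limit, so no step between them can be read. The compounds shown leave open what number either compound would give, and so whether going from hexyl to propyl on the chain changes the half-maximal cytotoxic concentration at all on this shared core.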